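This account rests on a few compounds, and the source may have more. Where it says the series, first, only, none or still open, it means among the compounds named here.

In an ADME assay (liver) for metabolic stability, with Liver microsome (Rattus norvegicus) as the target, using microsomes and NADPH, with a stated time of 30 min (on this read-out lower numbers stand for slow clearance and higher numbers for fast clearance), compound 1 (`C#CCC(O)(c1ccc(N2CCN(S(=O)(=O)c3ccc(N)nc3)C[C@@H]2C#CC)cc1)C(F)(F)F`) gives 59 mL.min-1.g-1 and compound 2 (`CC#C[C@H]1CN(S(=O)(=O)c2ccc(N)nc2)CCN1c1ccc(C(O)(COC)C(F)(F)F)cc1`) gives 93 mL.min-1.g-1, so these two values stand within the scatter of each other. Compound 3 (`CC#C[C@H]1CN(S(=O)(=O)c2ccc(N)nc2)CCN1c1ccc(C(C)=O)cc1`) differs from compound 2 by a group of 3 heavy atoms (2 carbon, 1 oxygen; no ring) in place of a group of 9 heavy atoms (4 carbon, 2 oxygen, 3 fluorine; no ring), on an aromatic carbon, with acetyl as the entering group. Among the compounds with values here, the only measured step, a 1.6-fold higher number from compound 1 to compound 2 (0.20 log units; within the scatter), lies within the scatter and touches just one part of the group that leaves, so it offers weak guidance. The expected change is a 1.2-fold lower number from compound 2 to compound 3 (0.07 log units; within the scatter), which means none beyond the scatter. For compound 3 the estimate is 80 mL.min-1.g-1, with an expected range of 35 mL.min-1.g-1 to 180 mL.min-1.g-1.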

Compound 3, intrinsic clearance in microsomes: 249 mL.min-1.g-1
Beside the measured number, compound 3's estimate is 3.1-fold (0.49 log units) below it; measured number above the stated range.
By their numbers in this assay, from the lowest: compounds 1 and 2 (each within the scatter of the next); then compound 3.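

With acetyl on the aromatic carbon, the shift is a 2.7-fold higher number from compound 2 to compound 3 (0.43 log units; beyond the scatter) and a 4.2-fold higher number from compound 1 to compound 3 (0.63 log units; beyond the scatter) in this assay and both steps lie beyond the scatter. The earlier step changed only one part of the larger group and stayed within the scatter, so this position shows a real difference only when the whole group is exchanged. No measurement shown offers an explanation for this difference. Going by these compounds, it remains open whether the rise follows from gaining the carbonyl or from losing the trifluoromethyl and hydroxyl groups. A nitrile or a 1-hydroxyethyl group on the same aromatic carbon would help separate these possibilities.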